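A few compounds are considered here, and "the series" means these few. Any claim that something is new, unique, unknown or untested is made for them only; others in the source may bear on it.

The measured compounds:
compound 1, `Cc1cccc(-c2csc(N)c2C(=O)OCc2ccccc2)c1`, gives 68% in an assay on isolated protein for inhibition of protein kinase C zeta type (Homo sapiens), with stated times of 1 h and 2.5 min, tested at 30 uM; a lower number here means less inhibition, a higher number more inhibition at the concentration tested (going by the name of the read-out);
compound 2, `Cc1ccc(-c2csc(N)c2C(=O)OCc2ccccc2)cc1`, gives 60% in this assay;
compound 3, `COc1cccc(-c2csc(N)c2C(=O)OCc2ccccc2)c1`, gives 57% in this assay.

Compound 2 stands second highest of the three numbers. Its nearest neighbour is compound 3, and the step of a number 3 percentage points lower from compound 2 to compound 3 (within the scatter) stays within the scatter; the step of a number 8 percentage points lower from compound 1 to compound 2 (within the scatter) stays within the scatter as well. Going by the values given here, the one step that reaches beyond the scatter is a number 11 percentage points lower from compound 1 to compound 3 (beyond the scatter), and it is modest.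

Compound 4, `Nc1scc(-c2ccc(C(F)(F)F)cc2)c1C(=O)OCc1ccccc1`, is the unmeasured member of the set. It differs from compound 2 in one place: trifluoromethyl in place of methyl on an aromatic carbon. Among the compounds with values here, no measured step exchanges a methyl for a trifluoromethyl, so the expectation rests on the general picture of this small series, in which the three changes on the pendant phenyl ring moved the read-out in this assay little. Compound 4 is therefore expected to show a number 2 percentage points lower from compound 2 to compound 4 (within the scatter), no step beyond the scatter. Compound 4 is estimated at 58%, with a range from 40% to 75%.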

Compound 4, a percentage reported as inhibition, at one concentration (the size of the read-out at that concentration, not a potency): 21%
Beside the measured number, compound 4's estimate is 37 percentage points above it, outside the stated range (below it).
By their numbers in this assay, from the lowest: compound 4; then compounds 3, 2 and 1 (each within the scatter of the next, the first and the last beyond it).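

Trifluoromethyl in place of methyl, on the aromatic carbon para to a large group, brings a number 39 percentage points lower from compound 2 to compound 4 (beyond the scatter) in this assay. Going by these compounds alone, the earlier changes on this ring moved the read-out far less, with a number 8 percentage points lower from compound 1 to compound 2 (within the scatter) and the largest of them a number 11 percentage points lower from compound 1 to compound 3 (beyond the scatter), so this is the first sign that the number can depend strongly on the group at this carbon. Nothing available bears on why this exchange has so large an effect.

The compounds shown leave open whether the drop is particular to trifluoromethyl or would also appear with a chlorine atom, a nitrile or a longer chain at this carbon. They also leave open how trifluoromethyl would behave at the place of the methyl in compound 1.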